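Ethyl in place of trifluoromethyl on the phenyl ring

This account rests on a few compounds, and the source may have more. Where it says the series, first, only, none or still open, it means among the compounds named here.

Compound 1, `Cc1ccc(-n2cc(CNC(=O)c3cccc4c3cnn4C(C)C)nn2)cc1`, in a functional assay on MCF7 cells (Homo sapiens) for inhibition, read by MTT assay, with a stated time of 72 h; on this read-out lower numbers stand for stronger inhibition and higher numbers for weaker inhibition: > 40000 nM
Compound 2, `CC(C)n1ncc2c(C(=O)NCc3cn(-c4ccc(C(F)(F)F)cc4)nn3)cccc21`, in this assay: > 40000 nM

Both numbers shown are limits of the assay rather than measured values. In this assay compound 1 gives only the limit > 40000 nM. Compound 2 likewise gives only the limit > 40000 nM. Accordingly the one measured step, a step that the two limits leave unreadable from compound 1 to compound 2, cannot be read in size or direction; all that the two compounds share is the limit of > 40000 nM in this assay, at which 2 of the 2 values shown sit. Compound 3, `CCc1ccc(-n2cc(CNC(=O)c3cccc4c3cnn4C(C)C)nn2)cc1`, differs from compound 2 by ethyl in place of trifluoromethyl on an aromatic carbon. Going by the values given here, the only measured step touching this position is the unreadable one, so it offers no expectation of a change beyond the scatter in either direction. Compound 3 is therefore expected to give 60000 nM (range 15000 nM to 250000 nM) in this assay, most probably again reported only as a limit. That expectation corresponds to a step that the limit leaves unreadable from compound 2 to compound 3.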

Compound 3, half-maximal inhibitory concentration: > 40000 nM
Compound 3: only a limit was reported (the forecaster's own chance of this, stated with the estimate: 85%); the middle value does not contradict the limit.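

No new step can be read: the steps linking compound 1, compound 2 and compound 3 all run between limits, and the three compounds share one result: the limit of > 40000 nM in this assay, at which 3 of the 3 values shown sit.

The compounds shown leave open whether methyl, trifluoromethyl or ethyl on the phenyl ring makes any difference to inhibition in this assay.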